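This account rests on a few compounds, and the source may have more. Where it says the series, first, only, none or still open, it means among the compounds named here.

Compound 2, `Cc1nc2ccc(CN(CCN)c3ccc(C(=O)N[C@@H](CCC(=O)O)C(=O)O)c(F)c3)cc2c(=O)[nH]1`, is the weaker of the two measured compounds in a functional assay on L1210 cells (Mus musculus) for inhibition; a higher number here means a weaker inhibitor, a lower number a stronger inhibitor: it gives 2700 nM, while compound 1, `C=CCN(Cc1ccc2nc(C)[nH]c(=O)c2c1)c1ccc(C(=O)N[C@@H](CCC(=O)O)C(=O)O)cc1`, gives 170 nM, a gap beyond the usual scatter. Within the data shown here, no single-change step between measured compounds exists here, so the structural change from compound 2 to compound 3 must be judged without a direct precedent.

Compound 3, `Cc1nc2ccc(CN(CC#N)c3ccc(C(=O)N[C@@H](CCC(=O)O)C(=O)O)c(F)c3)cc2c(=O)[nH]1`, differs from compound 2 in one place: cyano in place of aminomethyl on a saturated chain carbon bound to a nitrogen on an aromatic ring. Cut one bond further out, the change reads 2-aminoethyl to cyanomethyl, so one hydrogen-bond donor is lost and the chain keeps one acceptor.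

Among the measured compounds shown here, the only guidance is that compound 1, which carries a short neutral allyl chain on the same nitrogen and no fluorine on the benzamide ring, is considerably stronger than compound 2. On that basis the account expects a moderate step from compound 2 to compound 3 toward a lower number, a 3.9-fold lower number from compound 2 to compound 3 (0.59 log units; beyond the scatter), though with wide uncertainty. Compound 3 is therefore estimated at 700 nM, within a range of 150 nM to 3000 nM.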

Compound 3, half-maximal inhibitory concentration: 34 nM
The estimate for compound 3 lay 21-fold (1.31 log units) above the measured number, outside the stated range (below it).
By their numbers in this assay, from the lowest: compound 3; then compound 1; then compound 2.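

In this assay, putting cyano in place of aminomethyl on a saturated chain carbon bound to a nitrogen on an aromatic ring gives a 79-fold lower number from compound 2 to compound 3 (1.90 log units; beyond the scatter), a large step that shows inhibition in this pair to be highly sensitive to the chain at this place. The heavy-atom count of the exchanged groups stays the same, and the hydrogen-bond acceptor count stays the same, so the large step arises without any change in either count; what differs is the loss of a hydrogen-bond donor and the arrival of a triple bond. Nothing measured here bears on why this step is so large.

Among these compounds, the single pair leaves open whether the gain goes with the loss of the amine or with the presence of the nitrile itself, and how a 2-hydroxyethyl chain, a prop-2-ynyl chain or a longer chain ending in a nitrile would stand at this place. Among the compounds shown here, the contribution of the fluorine also stays open, as compound 1, the only compound without it, differs from the other two in more than one place.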